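A few compounds are considered here, and "the series" means these few. Any claim that something is new, unique, unknown or untested is made for them only; others in the source may bear on it.

Measured compounds in an ADME assay on SK-OV-3 cells (Homo sapiens) for cytotoxicity; on this read-out higher numbers stand for an effect only at larger amounts of compound and lower numbers for an effect already at smaller amounts:
Compound 1 `O=C1NC[C@@H](c2c[nH]c3ccccc23)N[C@H]1c1c[nH]c2ccccc12` gives 9.64 ug/mL.
Compound 2 `O=C(C1=NC(c2c[nH]c3cc(Br)ccc23)CN1)c1c[nH]c2ccccc12` gives 3.71 ug/mL.
Compound 3 `O=C(C1=NC(c2c[nH]c3cc(Br)ccc23)CN1)c1c[nH]c2cc(Br)ccc12` gives 4.81 ug/mL.

Compound 1 has the highest of the three numbers; its gap to compound 3 lies within the scatter, while its gap to compound 2 lies beyond it. Compound 3 differs from compound 2 by bromo in place of hydrogen on an aromatic carbon. The difference between the core of compound 1 and the core of compound 2 is not broken down here. Compound 4 `O=C1NC[C@@H](c2c[nH]c3ccccc23)N[C@H]1c1c[nH]c2cc(Br)ccc12` has not been measured; it differs from compound 1 by bromo in place of hydrogen on an aromatic carbon, the same change at the same place. In this assay the step from compound 1 to compound 4 is expected to be a 1.1-fold higher number from compound 1 to compound 4 (0.06 log units; within the scatter), because the same change gave a 1.3-fold higher number from compound 2 to compound 3 (0.11 log units; within the scatter). Compound 4 is therefore estimated at 11 ug/mL, between 5.5 ug/mL and 22 ug/mL.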

Compound 4, concentration for half-maximal effect: 5.67 ug/mL
Compound 4: the middle estimate sits 1.9-fold (0.29 log units) above what was measured, and the stated range covers the measured number.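

In this assay, bromo in place of hydrogen on an aromatic carbon gives a 1.7-fold lower number from compound 1 to compound 4 (0.23 log units; within the scatter). Set beside the earlier step, the results on the two cores do not differ by more than repeated measurements would allow: the same change on two cores in this assay, a 1.3-fold higher number (0.11 log units; within the scatter) from compound 2 to compound 3 and a 1.7-fold lower number (0.23 log units; within the scatter) from compound 1 to compound 4, 2.2-fold (0.34 log units) apart, within the scatter of two such steps. This shows that neither step lies beyond the scatter on these two cores, but it does not show that the change carries a fixed size or direction from one core to another, nor that its effect depends on the core. On these data alone, it remains open whether an amine or a carboxylic acid in place of the bromo would give a step beyond the scatter. As far as these compounds go, the size of the bromo step on a third core also remains open.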